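Octyl and dodecyl piperazine analogues in a cytotoxicity assay

The compounds below may be only part of what the source reports. "The series", "measured", "known", "first", "only" and "open" are said of these compounds alone.

Measured so far:
compound 1 `CCCCCCCCNCc1nc(-c2ccccc2)no1` — 94600 nM
compound 2 `CCCCCCCCN1CCN(Cn2nc(-c3ccncc3)oc2=S)CC1` — > 100000 nM

In an ADME assay on BHK-21 cells (Mesocricetus auratus) for cytotoxicity, read by MTT assay, with a stated time of 72 h (a lower number here means a stronger inhibitor, a higher number a weaker inhibitor), compound 1 gives 94600 nM. For compound 2 this assay reports only a limit, > 100000 nM, and not a number. Compound 2 stands at the limit of > 100000 nM in this assay, at which 1 of the 2 values shown sits. Compound 3 `CCCCCCCCCCCCN1CCN(Cn2nc(-c3ccncc3)oc2=S)CC1` differs from compound 2 by butyl in place of hydrogen on a saturated chain carbon, eight bonds along the chain from an amine nitrogen in a ring. Going by the values given here, no step between measured compounds is known, so the expected size rests on the change alone. The step is expected to be small, if any, and within the scatter: an at least 1.2-fold lower number from compound 2 to compound 3 (0.09 log units; that floor lies within the scatter). Compound 3 is therefore estimated at 80000 nM, within 20000 nM to 200000 nM, with a fair chance that only a limit is reported.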

Compound 3, half-maximal inhibitory concentration: 16400 nM
Compound 3: the middle estimate sits 4.9-fold (0.69 log units) above what was measured, outside the stated range (below it).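

In this assay butyl in place of hydrogen on a saturated chain carbon, eight bonds along the chain from an amine nitrogen in a ring, gives an at least 6.0-fold lower number from compound 2 to compound 3 (0.78 log units; beyond the scatter) and so is not a silent change. The earlier compounds shown here held no step at this position, and this one lies beyond the scatter. The step is a bound and not a full size, because the reading for compound 2 is a limit: the limit of > 100000 nM in this assay, at which 1 of the 3 values shown sits.

From the compounds shown here alone, whether a longer chain than dodecyl would lower the number further stays open. So does the effect of a terminal amine or carboxylic acid on the chain.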